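The compounds below may be only part of what the source reports. "The series", "measured", "known", "first", "only" and "open" are said of these compounds alone.

Compound 1 `COc1cc(OC)c(-c2coc3cc(OCC(=O)c4cccc(C(F)(F)F)c4)ccc3c2=O)cc1OC`: in a functional assay on A-375 cells (Homo sapiens) for antiproliferative activity, read by MTT assay, with a stated time of 24 h (on this read-out lower numbers stand for stronger inhibition and higher numbers for weaker inhibition), compound 1 gives > 10000 nM, a limit of the assay rather than a number (the limit of > 10000 nM in this assay, at which 1 of the 2 values shown sits).
Compound 2 `COc1cc(OC)c(-c2coc3cc(OCc4ccccc4C)ccc3c2=O)cc1OC`: in this assay compound 2 gives 1360 nM.

Compound 2 thus stands as the only number shown. Compound 3 `COc1cc(OC)c(-c2coc3cc(OCc4ccccc4Br)ccc3c2=O)cc1OC` differs from compound 2 by bromo in place of methyl on an aromatic carbon. Among the measured compounds shown here, the one measured step, an at least 7.3-fold lower number from compound 1 to compound 2 (0.86 log units; beyond the scatter), swaps a whole group and does not bear on this small change. With nothing pointing either way, no step beyond the scatter is expected, so compound 3 is estimated at 1400 nM, between 500 nM and 4500 nM, a step of a 1.0-fold higher number from compound 2 to compound 3 (0.01 log units; within the scatter) expected.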

Compound 3, half-maximal inhibitory concentration: 2850 nM
Beside the measured number, compound 3's estimate is 2.0-fold (0.31 log units) below it, and the stated range covers the measured number.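

Swapping one heavy atom for another on this aromatic carbon, ortho to a large group, already moves the result in this assay: a 2.1-fold higher number from compound 2 to compound 3 (0.32 log units; beyond the scatter). Even so, the bromo compound keeps its lead over the ketone-bearing side chain, with an at least 3.5-fold lower number from compound 1 to compound 3 (0.54 log units; beyond the scatter). The value for compound 1 is a limit of the assay, not a number: the limit of > 10000 nM in this assay, at which 1 of the 3 values shown sits.

One pair of groups cannot show what this carbon favours. Going by these compounds, how a fluoro, a methoxy or an amine would fare on the same carbon remains open.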